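Removing the Acetyl Group from Compound 2

The compounds below may be only part of what the source reports. "The series", "measured", "known", "first", "only" and "open" are said of these compounds alone.

- Compound 1 `CC1=NN(c2ccccc2)C(=O)/C1=N/Nc1cccc(-c2nc3ccccc3s2)c1`: 12300 nM
- Compound 2 `CC(=O)N1N=C(C)/C(=N\Nc2cccc(-c3nc4ccccc4s3)c2)C1=O`: 12300 nM

In a functional assay on A549 cells (Homo sapiens) for inhibition (on this read-out higher numbers stand for weaker inhibition and lower numbers for stronger inhibition), compound 2 gives 12300 nM and so stands level with compound 1 at the digits shown. The next compound, compound 3 `CC1=NNC(=O)/C1=N/Nc1cccc(-c2nc3ccccc3s2)c1`, is still unmeasured. It differs from compound 2 in one place: hydrogen in place of acetyl on an amide-type nitrogen in a ring. In words, this is hydrogen in place of acetyl on an amide-type nitrogen in a ring.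

Among the measured compounds shown here, only one measured step bears on this change. It concerns the same kind of nitrogen: no change at the digits printed from compound 1 to compound 2 (within the scatter), with acetyl in place of phenyl. Exchanging those two groups therefore left the value unmoved. For the measured compounds named here, no measured compound carries hydrogen there, however, and a single step is thin evidence, so the range must stay wide. In this assay no step beyond the scatter is expected, in either direction. The estimated step is a 1.0-fold lower number from compound 2 to compound 3 (0.01 log units; within the scatter) as a best guess. Compound 3 is expected at about 12000 nM with an estimated range from 5000 nM to 28000 nM as its limits of expectation.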

Compound 3, half-maximal inhibitory concentration: > 25000 nM
Compound 3: a limit, no number (the forecaster's own chance of this, stated with the estimate: 15%); at least 2.0-fold (0.31 log units) between middle value and limit.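

In this assay compound 3, with only hydrogen on the amide-type nitrogen in a ring, gives a limit of the assay and not a number: the limit of > 25000 nM in this assay, at which 1 of the 3 values shown sits. Set against the two substituted compounds, the change reads as an at least 2.0-fold higher number from compound 2 to compound 3 (0.30 log units; that floor lies within the scatter) and as an at least 2.0-fold higher number from compound 1 to compound 3 (0.30 log units; that floor lies within the scatter) and both of these figures are floors, not measured sizes. Among the compounds shown here, the earlier exchange of phenyl for acetyl on this nitrogen gave no change at the digits printed from compound 1 to compound 2 (within the scatter) and showed only that these two groups stand level, whereas hydrogen is the first group here to leave a limit in place of a number, although floors within the scatter cannot establish a real rise.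

The compounds shown leave open how far past the limit compound 3 lies, and so whether having a group on this nitrogen matters at all or whether phenyl and acetyl merely happen to read alike. A methyl group, a longer alkyl chain or a benzyl group on the same nitrogen would show whether a small carbon group is enough to give a readable number, and whether any group there can bring the number lower than in compound 1.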